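Bromo to Trifluoromethyl: Expected Cytotoxicity of Compound 3

The compounds below may be only part of what the source reports. "The series", "measured", "known", "first", "only" and "open" are said of these compounds alone.

compound 1 `CCC1(Cc2ccccc2)OS(=O)(=O)C=C1OCc1ccc([N+](=O)[O-])cc1` — >= 80000 nM
compound 2 `CCC1(Cc2ccccc2)OS(=O)(=O)C=C1OCc1ccc(Br)cc1` — 80000 nM

In an ADME assay on HEL cells (Homo sapiens) for cytotoxicity, with a stated time of 3 days (on this read-out higher numbers stand for lower toxicity in this test and lower numbers for higher toxicity in this test), compound 2 gives 80000 nM, the only plain number shown. For compound 1 the result >= 80000 nM is a limit of the assay and not a number. As far as these compounds go, the step from compound 1 to compound 2, bromo in place of nitro on an aromatic carbon, is a number no higher from compound 1 to compound 2 (the limit leaves the size open); its size stays open because of the limit of >= 80000 nM in this assay, at which 1 of the 2 values shown sits. Compound 3 `CCC1(Cc2ccccc2)OS(=O)(=O)C=C1OCc1ccc(C(F)(F)F)cc1` has not yet been measured and differs from compound 2 by trifluoromethyl in place of bromo on an aromatic carbon. Going by the values given here, only that one measured step bears on this change, and its size is not readable, so no shift beyond the scatter is expected. For compound 3 the estimate is 80000 nM, ranging from 40000 nM to 160000 nM, an expected step of no change at the digits printed from compound 2 to compound 3 (within the scatter).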

Compound 3, minimum cytotoxic concentration: >= 16000 nM
Compound 3: only a limit was reported (the forecaster's own chance of this, stated with the estimate: 50%); the middle value is on the limit's open side.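

In this assay compound 3 gives >= 16000 nM, a limit and not a number. No step from compound 1 or compound 2 to compound 3 can be read: the limit of >= 16000 nM in this assay, at which 1 of the 3 values shown sits.

The compounds shown leave open whether trifluoromethyl, bromo and nitro differ at all in their effect on this read-out.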